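The source may report more compounds than this note shows. Statements on the series, on what has been measured and on what is new or still open speak of the compounds shown alone.

Measured in an ADME assay on brain (Rattus norvegicus) for protein binding; on this read-out lower numbers stand for a smaller free fraction and higher numbers for a larger free fraction:
- compound 1 `Cc1c(C(C)OC(=O)Nc2ccccc2)oc2ncnn12`: 0.08
- compound 2 `Cc1c(C(C)OC(=O)Nc2cccc(F)c2)oc2ncnn12`: 0.017

Going by the values given here, of these two, compound 1 has the higher number, and compound 2 is its only neighbour. The next compound to be read is compound 3 `Cc1c(C(C)OC(=O)Nc2ccccc2)oc2nc(-c3cccs3)nn12`, still unmeasured in this assay. Relative to compound 1, the change is thiophen-2-yl in place of hydrogen on an aromatic carbon.

Among the compounds with values here, only one measured step bears on this, and only indirectly: a 4.7-fold lower number from compound 1 to compound 2 (0.67 log units; beyond the scatter), for fluoro in place of hydrogen on an aromatic carbon. That step is modest, and it sits at a different place from the new group. Within the data shown here, no measured step covers a change at the carbon altered in compound 3, and two compounds establish no trend. Among the measured compounds shown here, still, the one substitution on compound 1 lowered the number, and thiophen-2-yl is a much larger addition than fluoro, so a step of similar size in the same direction is expected, with wide uncertainty.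

The expected change is a 4.0-fold lower number from compound 1 to compound 3 (0.60 log units; beyond the scatter). For compound 3 the estimated value is 0.02, with an expected range of 0.006 to 0.06.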

Compound 3, unbound fraction in the brain assay: < 0.001
Compound 3: a limit, no number; the forecaster's own chance of this, stated with the estimate: 5%; middle value at least 20-fold (1.30 log units) from the limit.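

In the brain assay compound 3 reads < 0.001, which is a limit of the assay and not a number. On the aromatic carbon between two ring nitrogen atoms, thiophen-2-yl in place of hydrogen gives an at least 80-fold lower number from compound 1 to compound 3 (1.90 log units; beyond the scatter), so this position on the core of compound 1 can carry a much larger step than the only earlier one, a 4.7-fold lower number from compound 1 to compound 2 (0.67 log units; beyond the scatter). In a physicochemical assay for lipophilicity, at pH 7.4 (on this read-out higher numbers stand for higher lipophilicity and lower numbers for lower lipophilicity), compound 1 gives 2.3 and compound 3 gives 3.7. The smaller free fraction of compound 3 may go with higher lipophilicity, as read in the physicochemical assay: the measured distribution coefficient of compound 1, 2.3, and of compound 3, 3.7, a number 1.40 log units higher (beyond the scatter)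

A single group at this carbon cannot separate any contribution of lipophilicity from one particular to thiophen-2-yl, and the limit leaves the size of the step open. A methyl group or an amine such as morpholin-4-yl at the same carbon would show whether the free fraction in the brain assay follows the distribution coefficient or depends on the aromatic ring itself.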